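Pyridin-2-yl amine replacing the indole of compound 2

The source may report more compounds than this note shows. Statements on the series, on what has been measured and on what is new or still open speak of the compounds shown alone.

Among the measured compounds shown here, compound 2 `Cn1ccc2cc(Nc3ncc4cc(S(=O)(=O)c5ccc(F)cc5F)c(=O)n(C)c4n3)ccc21` gives 750 nM in a functional assay on DU-145 cells (Homo sapiens) for inhibition, read by trypan blue exclusion, with a stated time of 72 h (on this read-out lower numbers stand for stronger inhibition and higher numbers for weaker inhibition), and stands lowest of the three numbers so far. Compound 1 `Cn1c(=O)c(S(=O)(=O)c2ccc(F)cc2F)cc2cnc(Nc3ccc4[nH]c(C(=O)O)cc4c3)nc21` gives 10000 nM in this assay, and compound 3 `COC(=O)Cn1ccc2cc(Nc3ncc4cc(S(=O)(=O)c5ccc(F)cc5F)c(=O)n(C)c4n3)ccc21` gives 5000 nM in this assay. The move to compound 4 `Cn1c(=O)c(S(=O)(=O)c2ccc(F)cc2F)cc2cnc(Nc3ccccn3)nc21` is pyridin-2-yl in place of 1-methyl-1H-indol-5-yl on a nitrogen on an aromatic ring. For the measured compounds named here, no measured step removes the indole itself; the nearest are a 13-fold lower number from compound 1 to compound 2 (1.12 log units; beyond the scatter) and a 6.7-fold higher number from compound 2 to compound 3 (0.82 log units; beyond the scatter), both showing that every variation of the 1-methyl-1H-indol-5-yl group so far has raised the number. Replacing it entirely by the smaller pyridin-2-yl is a bigger change than either, so a rise is expected, of about a 6.7-fold higher number from compound 2 to compound 4 (0.82 log units; beyond the scatter). Compound 4 is therefore expected to give 5000 nM in this assay, within a range of 1500 nM to 20000 nM.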

Compound 4, half-maximal inhibitory concentration: 75000 nM
Compound 4: middle estimate off by 15-fold (1.18 log units), on the low side; measured number above the stated range.
By their numbers in this assay, from the lowest: compound 2; then compounds 3 and 1 (each within the scatter of the next); then compound 4.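

In this assay, replacing the whole 1-methyl-1H-indol-5-yl group on this nitrogen costs far more than any change made on the indole: pyridin-2-yl gives a 100-fold higher number from compound 2 to compound 4 (2.00 log units; beyond the scatter), the largest step in the series. Even the 2-carboxy-1H-indol-5-yl group, the poorer of the two indoles compared here, does better than pyridin-2-yl, with a 7.5-fold higher number from compound 1 to compound 4 (0.88 log units; beyond the scatter). Nothing available here accounts for this loss.

Going by these compounds, whether the loss goes with the missing five-membered ring or with the pyridine nitrogen remains open. A plain phenyl group or a pyridin-2-yl carrying an amine would help separate the two.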